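A few compounds are considered here, and "the series" means these few. Any claim that something is new, unique, unknown or untested is made for them only; others in the source may bear on it.

In a functional assay on A549 cells (Homo sapiens) for cytotoxicity (on this read-out lower numbers stand for an effect already at smaller amounts and higher numbers for an effect only at larger amounts of compound), compound 1 `CCOc1cc(-c2ccccc2)nc2ccccc12` gives > 10 ug/mL, which is a limit and not a number. Compound 2 `CCCOc1cc(-c2ccccc2)nc2ccccc12` gives > 10 ug/mL, and this too is only a limit. The whole record so far is the limit of > 10 ug/mL in this assay, at which 2 of the 2 values shown sit. Compound 3 `CC(C)COc1cc(-c2ccccc2)nc2ccccc12` differs from compound 2 by methyl in place of hydrogen on a saturated chain carbon bound to two saturated chain carbons, a change that reads as propoxy to isobutoxy. Within the data shown here, the one measured step that bears on this change is a step that the two limits leave unreadable from compound 1 to compound 2, which also places a methyl in place of hydrogen on a saturated chain carbon. Neither a size nor a direction can be carried over from a step that the two limits leave unreadable from compound 1 to compound 2, so no step beyond the scatter is expected in this assay. The expected step is a step that the limit leaves unreadable from compound 2 to compound 3, and most likely the result will again be a limit. For compound 3 the estimated value is 15 ug/mL, with an expected range from 7 ug/mL to 40 ug/mL.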

Compound 3, half-maximal effective concentration: > 10 ug/mL
Compound 3: a limit, no number; the forecaster's own chance of this, stated with the estimate: 85%; the middle value does not contradict the limit.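

No new step can be read among compound 1, compound 2 and compound 3 in this assay, because each of them gives only a limit: the limit of > 10 ug/mL in this assay, at which 3 of the 3 values shown sit.

The compounds shown leave open where each true value lies and whether these chain changes shift the read-out at all.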